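Swapping a morpholine amide for a trimethoxybenzyl group

The compounds below may be only part of what the source reports. "The series", "measured", "known", "first", "only" and "open" are said of these compounds alone.

Compound 1 `COc1ccc(-c2nc3cc(/C=C4\SC(=O)N(CC(=O)N5CCOCC5)C4=O)ccc3[nH]2)cc1OC` is a benzimidazole-linked thiazolidinedione with a dimethoxyphenyl arm. In a functional assay on MDA-MB-231 cells (Homo sapiens) for inhibition, read by MTT assay, with a stated time of 48 h (a lower number here means a stronger inhibitor, a higher number a weaker inhibitor), compound 1 gives > 50000 nM. That figure is a limit of the measurement, not a number, so compound 1 stands at the limit of > 50000 nM in this assay, at which 1 of the 2 values shown sits, and its true potency is only known to be weak. Within the data shown here, compound 2 `COc1cc(OC)c(-c2nc3cc(/C=C4\SC(=O)N(CC(=O)N5CCOCC5)C4=O)ccc3[nH]2)cc1OC` carries one more methoxy group on the aromatic ring; in this assay compound 2 gives 21300 nM, and the step of an at least 2.3-fold lower number from compound 1 to compound 2 (0.37 log units; beyond the scatter) is the only measured change on record.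

Compound 3 `COc1ccc(-c2nc3cc(/C=C4\SC(=O)N(Cc5cc(OC)c(OC)c(OC)c5)C4=O)ccc3[nH]2)cc1OC` differs from compound 1 elsewhere: 3,4,5-trimethoxyphenyl in place of (morpholin-4-yl)carbonyl on a saturated chain carbon bound to an amide-type nitrogen in a ring. Among the measured compounds shown here, no measured step touches that place, so the step from compound 1 to compound 2, which concerns a different part of the molecule, gives no direct guide to the size or direction of the change, and the starting point is itself only a limit. The estimate therefore stays near where compound 1 sits, with a wide range toward modest improvement. For compound 3 the expected value in this assay is 30000 nM, within 8000 nM to 60000 nM, an expected step of an at least 1.6-fold lower number from compound 1 to compound 3 (0.22 log units; that floor lies within the scatter).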

Compound 3, half-maximal inhibitory concentration: 29100 nM
The estimate for compound 3 lay 1.0-fold (0.01 log units) above the measured number; the range from low to high includes it.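

The saturated chain carbon bound to an amide-type nitrogen in a ring had not been varied before, and compound 3 shows that this place tolerates a large change. In this assay, a group with a six-membered aromatic ring of carbon only, 3,4,5-trimethoxyphenyl, replaces (morpholin-4-yl)carbonyl, and the result is an at least 1.7-fold lower number from compound 1 to compound 3 (0.23 log units; that floor lies within the scatter). The true size of this step stays unknown, and it may be small or much larger, because compound 1 is held only by a limit: the limit of > 50000 nM in this assay, at which 1 of the 3 values shown sits.

The compounds shown carry only two groups at this place, so they cannot tell whether the result follows from the aromatic ring, from its three methoxy groups or from the loss of the morpholine amide, and a plain phenyl, a shorter amine or a carboxylic acid there would help to separate these. On these data alone, it also remains open whether the added methoxy group of compound 2 and the 3,4,5-trimethoxyphenyl group of compound 3 would add up when carried together on the shared core.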